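Aryl substituent swap: fluoro to hydroxy on the shared core

The source may hold more compounds than are shown below. What is called first, only, known or untested is meant among the compounds shown, and "the series" means these compounds.

Compounds 1 to 3 share one core and differ only in the group on the six-membered aromatic ring of carbon only: compound 1 `Cc1ccc(-c2nnc(SCCCN3CCN(c4nc5ccccc5o4)CC3)o2)cc1`, compound 2 `Clc1ccc(-c2nnc(SCCCN3CCN(c4nc5ccccc5o4)CC3)o2)cc1` and compound 3 `Fc1ccc(-c2nnc(SCCCN3CCN(c4nc5ccccc5o4)CC3)o2)cc1`. In a functional assay on A549 cells (Homo sapiens) for inhibition, read by MTT assay, with a stated time of 72 h (a higher number here means a weaker inhibitor, a lower number a stronger inhibitor), compound 1 gives 106000 nM, compound 2 gives 127000 nM and compound 3 gives 75700 nM. Compound 3 carries the lowest of the three numbers, but its separation from compound 1 and from compound 2 stays within the scatter, so no order among the three can be read. All three measured steps, a 1.2-fold higher number from compound 1 to compound 2 (0.08 log units; within the scatter), a 1.4-fold lower number from compound 1 to compound 3 (0.15 log units; within the scatter) and a 1.7-fold lower number from compound 2 to compound 3 (0.22 log units; within the scatter), stay within the scatter.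

Compound 4 `Oc1ccc(-c2nnc(SCCCN3CCN(c4nc5ccccc5o4)CC3)o2)cc1` is the next member: hydroxy in place of fluoro on an aromatic carbon. Going by the values given here, none of the measured steps brings in a hydroxy, so they bear on this change only by showing that exchanges of this group have so far moved this assay by nothing beyond the scatter. No step beyond the scatter is therefore expected here either. Compound 4 is estimated at 80000 nM, with a range from 30000 nM to 220000 nM. The expected step is a 1.1-fold higher number from compound 3 to compound 4 (0.02 log units; within the scatter).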

Compound 4, half-maximal inhibitory concentration: 181000 nM
For compound 4 the middle estimate is 2.3-fold (0.35 log units) below the measured one, within the range that was stated.
By their numbers in this assay, from the lowest: compounds 3, 1, 2 and 4 (each within the scatter of the next, the first and the last beyond it).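

In this assay, going by these compounds alone, hydroxy in place of fluoro is the first exchange at this position, para to a large group, to pass the scatter, though only modestly (a 2.4-fold higher number from compound 3 to compound 4 (0.38 log units; beyond the scatter)). Against chloro and methyl, hydroxy stays within the scatter (a 1.4-fold higher number from compound 2 to compound 4 (0.15 log units; within the scatter); a 1.7-fold higher number from compound 1 to compound 4 (0.23 log units; within the scatter)), so only the fluoro and hydroxy pair separates and no general penalty for hydroxy over the other three groups can be read. Nothing available accounts for this single separation.

Open, as far as these compounds go, is whether an amine, a methoxy or a carboxylic acid at this position would stay within the scatter of these four groups or pass it. Also open, from the compounds shown here alone, is whether the difference between fluoro and hydroxy would persist with a longer chain on the shared core.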